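Aryl Substituent Swap on the Shared Core

A few compounds are considered here, and "the series" means these few. Any claim that something is new, unique, unknown or untested is made for them only; others in the source may bear on it.

Compound 1 `CCCS(=O)(=O)Nc1ccc(F)c(C(=O)c2n[nH]c3ncc(-c4ccccc4)cc23)c1F`: 2.4%
Compound 2 `CCCS(=O)(=O)Nc1ccc(F)c(C(=O)c2n[nH]c3ncc(-c4ccccc4Cl)cc23)c1F`: 9.3%
Compound 3 `CCCS(=O)(=O)Nc1ccc(F)c(C(=O)c2n[nH]c3ncc(-c4ccccc4N)cc23)c1F`: 23%

In an assay for binding affinity to dual specificity mitogen-activated protein kinase kinase 4 (Homo sapiens), read by KINOMEscan, tested at 100 nM (a lower number here means a stronger effect, a higher number a weaker effect of the compound at the concentration tested), compound 3 gives the highest of the three numbers; a number 20.6 percentage points higher from compound 1 to compound 3 (beyond the scatter) and a number 13.7 percentage points higher from compound 2 to compound 3 (beyond the scatter) both lie beyond the scatter, so compound 3 binds more weakly than the other two. Compound 4 `CCCS(=O)(=O)Nc1ccc(F)c(C(=O)c2n[nH]c3ncc(-c4ccc(C)c(C)c4)cc23)c1F` differs from compound 3 by 3,4-dimethylphenyl in place of 2-aminophenyl on an aromatic carbon. For the measured compounds named here, no measured step covers this exact change. The nearest guides are the steps from compound 1, where a number 6.9 percentage points higher from compound 1 to compound 2 (within the scatter) stays within the scatter while a number 20.6 percentage points higher from compound 1 to compound 3 (beyond the scatter) is a modest rise. Removing the amino group is expected to bring compound 4 back toward compound 1, so a modest fall is expected: a number 16 percentage points lower from compound 3 to compound 4 (beyond the scatter). Compound 4 is therefore estimated at 7%, between 1% and 25%.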

Compound 4, a percentage reported as activity, at one concentration (the size of the read-out at that concentration, not a potency): 20%
Beside the measured number, compound 4's estimate is 13 percentage points below it, and the stated range covers the measured number.
By their numbers in this assay, from the lowest: compounds 1 and 2 (each within the scatter of the next); then compounds 4 and 3 (each within the scatter of the next).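

In this assay, losing the amino group does not by itself restore binding: 3,4-dimethylphenyl in place of 2-aminophenyl gives a number 3 percentage points lower from compound 3 to compound 4 (within the scatter) and the phenyl comparison gives a number 17.6 percentage points higher from compound 1 to compound 4 (beyond the scatter), so a group with no hydrogen-bond donor can also read well above phenyl. The same group also stands apart from 2-chlorophenyl, with a number 10.7 percentage points higher from compound 2 to compound 4 (beyond the scatter). No supporting measurement explains this result. Still open, going by these compounds, is whether one methyl group alone, rather than both, carries this step, and how a methoxy or fluoro group on the phenyl would read.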